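Compound 2 to compound 4: expected effect of losing chloro

The source may report more compounds than this note shows. Statements on the series, on what has been measured and on what is new or still open speak of the compounds shown alone.

In a functional assay on HT-29 cells (Homo sapiens) for inhibition, read by sulforhodamine B assay, with a stated time of 48 h, tested at 10 uM (a higher number here means more inhibition of growth at the concentration tested, a lower number less inhibition of growth), compound 2 `Clc1ccc(-c2cn3nc(-c4ccccc4)nc3s2)cc1` gives 26%, the lowest of three values and beyond the scatter of the other two. Compound 1 `COc1ccc(-c2nc3sc(-c4ccccc4)cn3n2)cc1` stands at 70% and compound 3 `COc1ccc(-c2nc3sc(-c4ccc(Cl)cc4)cn3n2)cc1` at 82.7%.

Compound 4 `c1ccc(-c2nc3sc(-c4ccccc4)cn3n2)cc1` differs from compound 2 by one change: hydrogen in place of chloro on an aromatic carbon. This is hydrogen in place of chloro on an aromatic carbon, or 4-chlorophenyl to phenyl.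

The closest evidence is the opposite change, a number 12.7 percentage points higher from compound 1 to compound 3 (beyond the scatter), a modest step beyond the scatter. Read backwards, it points to a lower number in this assay. The other measured step, a number 56.7 percentage points higher from compound 2 to compound 3 (beyond the scatter), is large and shows that methoxy in place of hydrogen matters in this series. The chloro step has only been measured with methoxy present, and compound 2 has none, so its size may not carry over.

A modest fall is therefore expected, which may not clear the scatter. The expected change is a number 10 percentage points lower from compound 2 to compound 4 (within the scatter). For compound 4, the estimated value is 16%, with an expected range of 3% to 35%.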

Compound 4, percent growth inhibition at one concentration: 9%
Compound 4: middle estimate off by 7 percentage points, on the high side; the range from low to high includes it.
By their numbers in this assay, from the lowest: compound 4; then compound 2; then compound 1; then compound 3.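

In this assay, the chloro step now has a reading without methoxy on the core, a number 17 percentage points lower from compound 2 to compound 4 (beyond the scatter), and its size carries over from the methoxy-bearing pair: the same change on two cores in this assay, a number 12.7 percentage points higher (beyond the scatter) from compound 1 to compound 3 and a number 17 percentage points higher (beyond the scatter) from compound 4 to compound 2, 4.3 percentage points apart, within the scatter of two such steps. The methoxy step also holds with and without chloro, with a number 61 percentage points lower from compound 1 to compound 4 (beyond the scatter) matching its earlier size: the same change on two cores in this assay, a number 56.7 percentage points higher (beyond the scatter) from compound 2 to compound 3 and a number 61 percentage points higher (beyond the scatter) from compound 4 to compound 1, 4.3 percentage points apart, within the scatter of two such steps. Across these four compounds the two changes therefore behave as independent and roughly additive, with none going against this, and the methoxy step is large where the chloro step is modest.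

On these data alone, it remains open whether the gain is specific to methoxy or would also come with a hydroxy group, an amine or a longer ether chain such as ethoxy. As far as these compounds go, it is equally open whether fluoro or bromo could stand in for chloro on the 4-chlorophenyl ring.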